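The source may report more compounds than this note shows. Statements on the series, on what has been measured and on what is new or still open speak of the compounds shown alone.

Compound 1 `CNC(=O)[C@@H]1C[C@H](N2CCc3c(cccc3OCCc3ccccc3)C2)CN1C(=O)c1ccc(CN)c(OC)c1` and compound 2 `CNC(=O)[C@@H]1C[C@H](N2CCc3c(ncnc3OCCC3CC3)C2)CN1C(=O)c1ccc(CN)c(OC)c1` give the two lowest numbers here: in an assay on isolated protein for inhibition of serine protease 1 (Homo sapiens), read by fluorescence (on this read-out lower numbers stand for stronger inhibition and higher numbers for weaker inhibition), compound 1 gives 3 nM and compound 2 gives 6 nM. Compound 3 `COc1cc(C(=O)N2C[C@@H](n3cc(C4CC4)nn3)C[C@H]2C(=O)N[C@H]2C[C@@H]2c2ccccc2)ccc1CN` stands at the high end of the three, with 960 nM in this assay, a gap beyond the scatter to both of the others. Compound 4 `COc1cc(C(=O)N2C[C@@H](n3cc(C4CC4)nn3)C[C@H]2C(=O)N[C@@H]2C[C@H]2c2ccccc2)ccc1CN` shares every atom and bond with compound 3, and the difference is one of configuration alone: the two compounds have the same atoms and bonds and differ only in configuration as drawn: 2 of 4 stereo elements differ; a stereocentre at a saturated ring carbon is drawn S in compound 3 and R in compound 4; a stereocentre at a saturated ring carbon is drawn R in compound 3 and S in compound 4. Among the measured compounds shown here, no measured pair shows what such a swap at two saturated ring carbons does, so the direction cannot be read from these data. The step from compound 3 to compound 4 in this assay is expected to be a 1.6-fold lower number from compound 3 to compound 4 (0.20 log units; within the scatter), with wide uncertainty. Compound 4 is estimated at 600 nM, somewhere between 100 nM and 4000 nM.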

Compound 4, half-maximal inhibitory concentration: 110 nM
Compound 4: middle estimate off by 5.5-fold (0.74 log units), on the high side; the range from low to high includes it.
By their numbers in this assay, from the lowest: compounds 1 and 2 (each within the scatter of the next); then compound 4; then compound 3.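

In this assay, the drawn configuration at these two saturated ring carbons matters by itself, with an 8.7-fold lower number from compound 3 to compound 4 (0.94 log units; beyond the scatter). Among the compounds shown here, none of the earlier compounds formed a pair that could show this. Because no atom or bond changes, the gap can be put down to configuration alone: the fact that compounds 3 and 4 differ only in the configuration as drawn

Which of the two ring carbons accounts for the step stays open, as no compound shown changes only one of them. Also open, going by these compounds, is whether the same swap would give a step of similar size with an amine or a carboxylic acid on that saturated ring.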